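Chloro to Bromo: a Step Expected Within the Scatter

A few compounds are considered here, and "the series" means these few. Any claim that something is new, unique, unknown or untested is made for them only; others in the source may bear on it.

Compound 1 `Nc1nc(N2CCCCC2)sc1C(=O)/C=C/c1ccccc1`: 16.6 ug/mL
Compound 2 `Nc1nc(N2CCCCC2)sc1C(=O)/C=C/c1ccc(Cl)cc1`: 12 ug/mL

In a functional assay on HepG2 cells (Homo sapiens) for antiproliferative activity, read by MTT assay, with a stated time of 48 h (on this read-out higher numbers stand for weaker inhibition and lower numbers for stronger inhibition), compound 1 gives 16.6 ug/mL and compound 2 gives 12 ug/mL. Compound 2 has the lower of the two numbers, but the gap a 1.4-fold lower number from compound 1 to compound 2 (0.14 log units; within the scatter) is within the scatter. Compound 3 `Nc1nc(N2CCCCC2)sc1C(=O)/C=C/c1ccc(Br)cc1` differs from compound 2 by bromo in place of chloro on an aromatic carbon. Within the data shown here, the only measured step that bears on this, a 1.4-fold lower number from compound 1 to compound 2 (0.14 log units; within the scatter), shows a chloro entering that ring changed little. In this assay compound 3 is therefore expected at 10 ug/mL, between 5 ug/mL and 20 ug/mL. The expected step is a 1.2-fold lower number from compound 2 to compound 3 (0.08 log units; within the scatter), nothing beyond the scatter.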

Compound 3, half-maximal inhibitory concentration: 17.4 ug/mL
The estimate for compound 3 lay 1.7-fold (0.24 log units) below the measured number; the range from low to high includes it.
By their numbers in this assay, from the lowest: compounds 2, 1 and 3 (each within the scatter of the next).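

Exchanging chloro for bromo on this aromatic carbon in this assay gives a 1.5-fold higher number from compound 2 to compound 3 (0.16 log units; within the scatter) and placing bromo where hydrogen stood gives a 1.0-fold higher number from compound 1 to compound 3 (0.02 log units; within the scatter) so that hydrogen, chloro and bromo at this place cannot be told apart on this read-out. With two halogens now tried, the position has tolerated a change of halogen without a step beyond the scatter. No outside measurement accounts for these small differences. Still open, from the compounds shown here alone, is whether an amine or a carboxylic acid at this place would move the number beyond the scatter.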